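The source may report more compounds than this note shows. Statements on the series, on what has been measured and on what is new or still open speak of the compounds shown alone.

Working notes on the series. Compound 1 `NS(=O)(=O)c1ccc(C(=O)N/N=C(/CS(=O)(=O)c2ccccc2)c2ccc(Br)cc2)cc1` gives 19100 nM in a functional assay on MCF7 cells (Homo sapiens) for antiproliferative activity, read by MTT assay; on this read-out lower numbers stand for stronger inhibition and higher numbers for weaker inhibition. Compound 2 `NS(=O)(=O)c1ccc(C(=O)N/N=C(/CS(=O)(=O)c2ccccc2)c2ccc(Cl)cc2)cc1` carries chloro in place of bromo on an aromatic carbon and in this assay gives 57000 nM; the change made a 3.0-fold higher number from compound 1 to compound 2 (0.47 log units; beyond the scatter). Compound 3 `NS(=O)(=O)c1ccc(N/C=C(\C(=O)c2ccc(Br)cc2)S(=O)(=O)c2ccccc2)cc1` gives 62700 nM in this assay, a number beside that of compound 2 and above that of compound 1; the difference between the core of compound 3 and the core of compound 1 is not broken down here. Compound 4 `NS(=O)(=O)c1ccc(N/C=C(\C(=O)c2ccc(Cl)cc2)S(=O)(=O)c2ccccc2)cc1` differs from compound 3 by chloro in place of bromo on an aromatic carbon, at a place that reads the same as for compound 2, so the same change. Among the compounds with values here, the step from compound 3 to compound 4 is expected to be a 2.4-fold higher number from compound 3 to compound 4 (0.38 log units; beyond the scatter), resting on the single earlier step of a 3.0-fold higher number from compound 1 to compound 2 (0.47 log units; beyond the scatter). Compound 4 is thus estimated at 150000 nM, between 50000 nM and 400000 nM.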

Compound 4, half-maximal inhibitory concentration: 15100 nM
The estimate for compound 4 lay 9.9-fold (1.00 log units) above the measured number, and the stated range ends above it.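

Chloro in place of bromo gave a 4.2-fold lower number from compound 3 to compound 4 (0.62 log units; beyond the scatter) in this assay, which runs against the earlier step on the other core: the same change on two cores in this assay, a 3.0-fold higher number (0.47 log units; beyond the scatter) from compound 1 to compound 2 and a 4.2-fold lower number (0.62 log units; beyond the scatter) from compound 3 to compound 4, 12-fold (1.09 log units) apart, beyond the scatter of two such steps. In this series the change therefore does not carry from the core of compound 1 to the core of compound 3, in either direction or size. With a single pair on each core, this does not show which part of the cores sets the gap, or how the change would read on any further core.

Open, on these data alone, is whether fluoro or iodo in place of the halogen would follow the step seen on either core. Also open, as far as these compounds go, is how an amine or a carboxylic acid would read there.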